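Three Amides at the Assay Ceiling, a Fourth Awaited

The compounds below may be only part of what the source reports. "The series", "measured", "known", "first", "only" and "open" are said of these compounds alone.

Compound 1 `COc1ccc(CNC(=O)/C=C/c2coc3cc(OC)ccc3c2=O)cc1` was tested in a functional assay on L02 cells (Homo sapiens) for inhibition, read by MTT assay, with a stated time of 48 h; on this read-out higher numbers stand for weaker inhibition and lower numbers for stronger inhibition. In this assay compound 1 gives > 200000 nM, which is a limit of the assay rather than a measured number. Compound 2 `Cc1ccc(CNC(=O)/C=C/c2coc3cc(O)ccc3c2=O)cc1` was tested in this assay as well. In this assay compound 2 gives > 200000 nM, again a limit. Compound 3 `O=C(/C=C/c1coc2cc(O)ccc2c1=O)Nc1ccccc1` is the third measured partner. In this assay compound 3 gives > 200000 nM, once more a limit. The one single-point step among these, a step that the two limits leave unreadable from compound 2 to compound 3, therefore cannot be read. All three measured values sit at the same ceiling, as the limit of > 200000 nM in this assay, at which 3 of the 3 values shown sit, records, so compound 1 stands nowhere that can be ranked against the others.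

Compound 4 `COc1ccc2c(=O)c(/C=C/C(=O)Nc3ccc(F)cc3)coc2c1` has not yet been measured in this assay. It differs from compound 1 in one place: 4-fluorophenyl in place of 4-methoxybenzyl on an amide-type nitrogen. Among the compounds with values here, no measured step bears directly on this change, since the only step available is unreadable. With every measured compound at the limit, the expectation is that compound 4 also sits at or near that ceiling, and the expected step of a number no higher from compound 1 to compound 4 (the limit leaves the size open) is none beyond the scatter. On that basis compound 4 is estimated at 200000 nM in this assay, within a range from 100000 nM to 400000 nM.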

Compound 4, half-maximal inhibitory concentration: > 200000 nM
Compound 4: no number, only a limit; the forecaster's own chance of this, stated with the estimate: 80%; the middle value lies on the limit itself.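

In this assay compound 4 gives > 200000 nM, which is a limit and not a number. Within the data shown here, compound 1 also stands at a limit, so no step from compound 1 to compound 4 can be read, and all the compounds share one ceiling: the limit of > 200000 nM in this assay, at which 4 of the 4 values shown sit. The compounds shown leave open how far their true values differ, and whether any change to the group on the amide nitrogen would give a measurable number in this assay.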